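A few compounds are considered here, and "the series" means these few. Any claim that something is new, unique, unknown or untested is made for them only; others in the source may bear on it.

In a functional assay on NCI-H460 cells (Homo sapiens) for inhibition, read by CCK-8 assay, with a stated time of 72 h, tested at 1 uM (on this read-out lower numbers stand for less inhibition of growth and higher numbers for more inhibition of growth at the one concentration tested), two compounds that share one core have been measured. Compound 1 (`CN(C)C(=O)c1cc2cnc(Nc3ccc(NC(=O)C4(C(=O)Nc5ccc(Cl)cc5)CC4)cc3)nc2n1C1CCCC1`) gives 21.3%, and compound 2 (`CN(C)C(=O)c1cc2cnc(Nc3ccc(NC(=O)C4(C(=O)Nc5ccccc5F)CC4)cc3)nc2n1C1CCCC1`) gives 28.2%. These two numbers lie within the scatter of each other, so compound 2 cannot be ranked against compound 1. Compound 3 (`CN(C)C(=O)c1cc2cnc(Nc3ccc(NC(=O)C4(C(=O)Nc5ccc(Br)cc5)CC4)cc3)nc2n1C1CCCC1`) departs from compound 2 by 4-bromophenyl in place of 2-fluorophenyl on an amide-type nitrogen. Within the data shown here, only one measured step bears on this change: a number 6.9 percentage points higher from compound 1 to compound 2 (within the scatter). That step exchanged 4-chlorophenyl for 2-fluorophenyl at the same amide-type nitrogen, and it did not clear the scatter. Among the measured compounds shown here, no measured compound yet carries 4-bromophenyl, so the expectation rests on this single small step and on compound 1, which has 4-chlorophenyl at that place and gives 21.3%. The expected change is a number 5.2 percentage points lower from compound 2 to compound 3 (within the scatter), an estimated step that stays within the scatter, so no real shift is predicted in this assay. The estimate for compound 3 is 23%, with an expected range from 12% to 36%.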

Compound 3, percent growth inhibition at one concentration: 31.5%
Estimate against measurement, compound 3: 8.5 percentage points below, and the stated range covers the measured number.
By their numbers in this assay, from the lowest: compounds 1, 2 and 3 (each within the scatter of the next, the first and the last beyond it).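

In this assay, putting 4-bromophenyl in place of 2-fluorophenyl on the amide-type nitrogen gives a number 3.3 percentage points higher from compound 2 to compound 3 (within the scatter) and so does not separate these two groups. Among these compounds, the comparison with compound 1 is more informative: bromo in place of chloro on an aromatic carbon gives a number 10.2 percentage points higher from compound 1 to compound 3 (beyond the scatter) and is the first step at this position to clear the scatter, although only modestly, while compound 2 remains within the scatter of both neighbours. No measurement of any property of these groups accompanies this result, so the step remains unexplained.

The compounds shown leave open whether the halogen or its place on the ring matters more, since 2-fluorophenyl differs from the other two groups in both respects, and 4-fluorophenyl or 2-bromophenyl would separate the two. They also leave open how far the trend from chloro to bromo extends, which 4-iodophenyl could test, and whether any halogen is needed at all, which unsubstituted phenyl or 4-methoxyphenyl on the same nitrogen could address.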